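Dienone series on a shared core: step from compound 3 to compound 4

The compounds below may be only part of what the source reports. "The series", "measured", "known", "first", "only" and "open" are said of these compounds alone.

Measured so far in a functional assay on MGC-803 cells (Homo sapiens) for antiproliferative activity, read by MTT assay, with a stated time of 48 h; on this read-out higher numbers stand for weaker inhibition and lower numbers for stronger inhibition:
- compound 1, `O=C(/C=C/c1ccc(Oc2cc(=O)oc3ccccc23)cc1)/C=C/c1ccccn1`, gives 19400 nM
- compound 2, `O=C(/C=C/c1ccc(Oc2cc(=O)oc3ccccc23)cc1)/C=C/c1cccnc1`, gives 24500 nM
- compound 3, `O=C(/C=C/c1ccc(Cl)cc1)/C=C/c1ccc(Oc2cc(=O)oc3ccccc23)cc1`, gives 55200 nM

Compound 3 stands at the highest number of the three. The step of a 2.8-fold higher number from compound 1 to compound 3 (0.45 log units; beyond the scatter) and the step of a 2.3-fold higher number from compound 2 to compound 3 (0.35 log units; beyond the scatter) both lie beyond the scatter and are modest in size, whereas the step of a 1.3-fold higher number from compound 1 to compound 2 (0.10 log units; within the scatter) is within the scatter, so the two pyridyl compounds cannot be ordered against each other.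

Compound 4, `COc1ccc(/C=C/C(=O)/C=C/c2ccc(Oc3cc(=O)oc4ccccc34)cc2)cc1OC`, is not yet measured. The change is 3,4-dimethoxyphenyl in place of 4-chlorophenyl on a double-bonded chain carbon bound to a double-bonded chain carbon. Going by the values given here, none of the measured steps swaps one carbon-only ring for another; the two steps ending at compound 3 only show that exchanging a pyridyl ring for 4-chlorophenyl raised the number modestly. That leaves no direct guide for 3,4-dimethoxyphenyl, so the expectation in this assay is for compound 4 a number not far from compound 3, with at most a modest movement in either direction, and the estimated step is a 1.4-fold lower number from compound 3 to compound 4 (0.14 log units; within the scatter). For compound 4 the estimate in this assay is 40000 nM, with a range from 15000 nM to 110000 nM.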

Compound 4, half-maximal inhibitory concentration: 49400 nM
Estimate against measurement, compound 4: 1.2-fold (0.09 log units) below; measured number inside the range.
By their numbers in this assay, from the lowest: compounds 1, 2, 4 and 3 (each within the scatter of the next, the first and the last beyond it).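

In this assay, going by these compounds alone, the exchange at this place, on a double-bonded chain carbon bound to a double-bonded chain carbon, gives a 1.1-fold lower number from compound 3 to compound 4 (0.05 log units; within the scatter) when 3,4-dimethoxyphenyl takes the place of 4-chlorophenyl, so this is the first comparison of two carbon-only rings here, and moving from 0 to 2 hydrogen-bond acceptors on that ring and from 7 to 10 heavy atoms leaves no readable difference. Against the pyridyl compounds the picture differs from that of compound 3: the exchange for pyridin-3-yl gives a 2.0-fold higher number from compound 2 to compound 4 (0.30 log units; within the scatter) and stays inside the scatter, while the exchange for pyridin-2-yl gives a 2.5-fold higher number from compound 1 to compound 4 (0.41 log units; beyond the scatter) and is modest, so only compound 1 separates from compound 4. No measurement is available that would explain any of these steps.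

The compounds shown leave open whether a plain phenyl ring, or a phenyl ring carrying a single methoxy group, would read any differently from compound 3 and compound 4. Also open, from the compounds shown here alone, is whether a ring bearing a dimethylamino group or a carboxylic acid at this place would move the number clearly in either direction.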